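The compounds below may be only part of what the source reports. "The series", "measured", "known", "first", "only" and "open" are said of these compounds alone.

Compound 1 `Nc1cc(N)c2nc(-c3ccccc3)c(Oc3ccc(Cl)c(Cl)c3)nc2c1`: < 100000 nM
Compound 2 `CCOC(=O)[C@H](CCC(=O)O)NC(=O)c1ccc(CNc2nc3cc(N)cc(N)c3nc2-c2ccccc2)cc1`: < 100000 nM
Compound 3 `COc1cc(CNc2nc3cc(N)cc(N)c3nc2-c2ccccc2)cc(OC)c1OC`: < 50200 nM

In a functional assay on COLO 205 cells (Homo sapiens) for inhibition, read by sulforhodamine B assay, with a stated time of 48 h (on this read-out lower numbers stand for higher toxicity in this test and higher numbers for lower toxicity in this test), compound 1 gives < 100000 nM, which is a limit of the assay and not a number. Compound 2 likewise gives only a limit in this assay, < 100000 nM. Compound 3 also gives a limit, < 50200 nM. Compound 1 thus sits at the limit of < 100000 nM in this assay, at which 2 of the 3 values shown sit, and cannot be placed relative to the other two on a number. Compound 4 `Nc1cc(N)c2nc(-c3ccccc3)c(Sc3ccc(Cl)c(Cl)c3)nc2c1` differs from compound 1 in one place: (3,4-dichlorophenyl)sulfanyl in place of 3,4-dichlorophenoxy on an aromatic carbon. Within the data shown here, no step between measured compounds exists, so nothing here sizes such a change; the expectation is a step no larger than the usual scatter, in no set direction, a step that the limit leaves unreadable from compound 1 to compound 4. Compound 4 is accordingly expected at 50000 nM, with a range from 10000 nM to 150000 nM, and most likely again reported only as a limit.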

Compound 4, concentration lethal to 50% of the cells: < 100000 nM
Compound 4: no number, only a limit (the forecaster's own chance of this, stated with the estimate: 70%); the middle value lies beyond the limit too.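

In this assay compound 1 gives < 100000 nM, a limit and not a number. Compound 4 gives < 100000 nM, again a limit, so no step can be read for (3,4-dichlorophenyl)sulfanyl in place of 3,4-dichlorophenoxy. The compounds shown leave open the size and direction of this change.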